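The source may hold more compounds than are shown below. What is called first, only, known or untested is meant among the compounds shown, and "the series" means these compounds.

Measured compounds:
- Compound 1 `O=C(NNc1ccccc1F)c1cccc(NS(=O)(=O)c2cnc(O)nc2O)c1`: 17000 nM
- Compound 2 `O=C(NNc1ccc(F)cc1)c1cccc(NS(=O)(=O)c2cnc(O)nc2O)c1`: > 20000 nM (a limit)
- Compound 3 `CCCCOc1ccc(C(=O)NNC(=O)c2cccc(NS(=O)(=O)c3cnc(O)nc3O)c2)cc1`: 9200 nM

All three were tested in a functional assay on OVCAR-3 cells (Homo sapiens) for antiproliferative activity, read by MTT assay, with a stated time of 24 h; a lower number here means a stronger inhibitor, a higher number a weaker inhibitor. Compound 3 gives 9200 nM and compound 1 gives 17000 nM, two values within the scatter of each other. Compound 2 gives > 20000 nM, which is a limit of the assay and not a number; this is the limit of > 20000 nM in this assay, at which 1 of the 3 values shown sits.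

Compound 4 `O=C(NNC(=O)c1cccc(NS(=O)(=O)c2cnc(O)nc2O)c1)c1ccc(F)cc1` has not yet been measured. It differs from compound 3 by fluoro in place of butoxy on an aromatic carbon, the same difference reading 4-butoxyphenyl to 4-fluorophenyl (fluoro in place of butoxy on an aromatic carbon).

Within the data shown here, no measured step removes a butoxy group. Among the measured compounds shown here, the only step available, an at least 1.1-fold higher number from compound 1 to compound 2 (0.07 log units; that floor lies within the scatter), moves a fluorine within a different group, so it bears on this change only loosely and shows nothing beyond the scatter. The two fluorophenyl compounds give only a weak hint of direction, as compound 1 sits at 17000 nM. The expected change, a 1.5-fold higher number from compound 3 to compound 4 (0.18 log units; within the scatter), therefore stays within the scatter, with a slight lean towards a higher number. For compound 4 the estimated value in this assay is 14000 nM, with an expected range of 7000 nM to 25000 nM.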

Compound 4, half-maximal inhibitory concentration: > 20000 nM
Compound 4 was reported as a limit (the forecaster's own chance of this, stated with the estimate: 30%); at least 1.4-fold (0.15 log units) between middle value and limit.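

In this assay, fluoro in place of butoxy on this aromatic carbon, para to a large group, gives an at least 2.1-fold higher number from compound 3 to compound 4 (0.33 log units; beyond the scatter). This is the only readable step in the set that clears the scatter, so it shows that this position is not indifferent to the change from 4-butoxyphenyl to 4-fluorophenyl, whereas moving a fluorine on the other group had shown nothing beyond the scatter. The second readable step, (4-fluorophenyl)carbonyl in place of 2-fluorophenyl on an amine nitrogen, gives an at least 1.1-fold higher number from compound 1 to compound 4 (0.07 log units; that floor lies within the scatter), and since that floor lies within the scatter it separates nothing. The step linking the two fluorinated compounds that are both reported as limits cannot be read, because each of them stands at the same limit: the limit of > 20000 nM in this assay, at which 2 of the 4 values shown sit.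

Going by these compounds, what remains open is whether the butoxy chain itself matters or whether a methoxy group, a propoxy chain or a longer chain such as hexyloxy at the same place would give a similar number. The compounds shown also do not tell how a hydroxy group or an amine would behave there.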